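Removing the methoxy from a bromo-to-methoxy pair

A few compounds are considered here, and "the series" means these few. Any claim that something is new, unique, unknown or untested is made for them only; others in the source may bear on it.

Of the compounds shown here, two built on one shared core have been measured. Compound 1 `N#CC1=C(N)OC(c2c[nH]c3ccccc23)=C(C#N)C1c1ccc(Br)cc1` carries a bromo group, and compound 2 `COc1ccc(C2C(C#N)=C(N)OC(c3c[nH]c4ccccc34)=C2C#N)cc1` carries a methoxy in its place on an aromatic carbon. In a functional assay, tested at 100 ug/mL (a lower number here means a weaker effect, a higher number a stronger effect of the compound at the concentration tested), compound 1 gives 14.6%, while compound 2 gives 20%. The difference between them, a number 5.4 percentage points higher from compound 1 to compound 2 (within the scatter), is smaller than the scatter of repeated measurements, so the two numbers cannot be told apart with confidence. Compound 2 therefore stands at the higher of the two numbers, but only by an amount the measurement cannot resolve.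

Compound 3 `N#CC1=C(N)OC(c2c[nH]c3ccccc23)=C(C#N)C1c1ccccc1` has not yet been measured. It differs from compound 2 as follows: hydrogen in place of methoxy on an aromatic carbon. Going by the values given here, the only step measured so far swaps one substituent for another at this very carbon, and that step stayed within the scatter. Taking the group away altogether is a different change, but with nothing else to go on, the step of a number 4 percentage points lower from compound 2 to compound 3 (within the scatter) is expected to be small, most likely also within the scatter and leaning slightly downward. Compound 3 is accordingly estimated to give 16%, with a plausible range from 8% to 26%.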

Compound 3, a percentage reported as activity, at one concentration (the size of the read-out at that concentration, not a potency): 19.3%
For compound 3 the middle estimate is 3.3 percentage points below the measured one, within the range that was stated.
By their numbers in this assay, from the lowest: compounds 1, 3 and 2 (each within the scatter of the next).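

Taking the methoxy away altogether, the change from 4-methoxyphenyl to phenyl, gives a number 0.7 percentage points lower from compound 2 to compound 3 (within the scatter) in this assay and so cannot be told apart from keeping the group. Hydrogen in place of bromo on the same aromatic carbon gives a number 4.7 percentage points higher from compound 1 to compound 3 (within the scatter) as well, so the plain phenyl compound now serves as a reference that the earlier pair lacked, and neither the bromo nor the methoxy compound separates from it. At this position, then, hydrogen, bromo and methoxy all lie within the scatter of one another, and nothing measured here offers a reason for that.

The compounds shown leave open whether a group of another kind on this carbon, such as an amine, a carboxylic acid or a longer chain, would move the read-out beyond the scatter. They also leave open whether a change elsewhere on the shared core, for instance to a nitrile, would count for more than any change at this position.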